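The source may report more compounds than this note shows. Statements on the series, on what has been measured and on what is new or still open speak of the compounds shown alone.

Compound 1 `Cc1cc(-c2cccc(F)c2)nnc1N1CCN(c2ncccn2)CC1` carries a 3-fluorophenyl group and in a functional assay on BV-2 cells (Mus musculus) for inhibition, read by ELISA, with a stated time of 16 h (a higher number here means a weaker inhibitor, a lower number a stronger inhibitor), gives 33500 nM, the lowest of the numbers recorded here. Compound 2 `Cc1cc(-c2ccc(F)cc2)nnc1N1CCN(c2ncccn2)CC1` gives 76300 nM in this assay, so the change of fluorine position amounts to a 2.3-fold higher number from compound 1 to compound 2 (0.36 log units; beyond the scatter). Compound 3 `Cc1cc(-c2ccncc2)nnc1N1CCN(c2ncccn2)CC1` reaches only a limit of this assay, > 100000 nM. Accordingly the move to the pyridyl analogue is an at least 2.9-fold higher number from compound 1 to compound 3 (0.47 log units; beyond the scatter). Compound 4 `Cc1cc(-c2ccc3[nH]ccc3c2)nnc1N1CCN(c2ncccn2)CC1` differs from compound 1 by 1H-indol-5-yl in place of 3-fluorophenyl on an aromatic carbon. Both measured replacements of the 3-fluorophenyl group weakened inhibition, though neither resembles an indolyl group, so the guide is thin. A step of roughly the size seen toward compound 2 is expected, namely a 1.3-fold higher number from compound 1 to compound 4 (0.13 log units; within the scatter). Compound 4 is therefore estimated at 45000 nM, within 12000 nM to 150000 nM.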

Compound 4, half-maximal inhibitory concentration: 85100 nM
Beside the measured number, compound 4's estimate is 1.9-fold (0.28 log units) below it; the range from low to high includes it.
By their numbers in this assay, from the lowest: compound 1; then compounds 2 and 4 (each within the scatter of the next). At a limit, above all of these: compound 3.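

Replacing 3-fluorophenyl with the larger 1H-indol-5-yl group, which brings a second ring and a hydrogen-bond donor, again gives no gain, with a 2.5-fold higher number from compound 1 to compound 4 (0.40 log units; beyond the scatter). Replacing the 4-fluorophenyl group with 1H-indol-5-yl gives a 1.1-fold higher number from compound 2 to compound 4 (0.05 log units; within the scatter), so these two groups cannot be told apart in this assay. Compound 3 stands at a limit. Replacing pyridin-4-yl with 1H-indol-5-yl gives an at least 1.1-fold lower number from compound 3 to compound 4 (0.07 log units; that floor lies within the scatter), so this step does not separate the two groups, because compound 3 has no exact number: the limit of > 100000 nM in this assay, at which 1 of the 4 values shown sits.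

On these data alone, whether any group at this position can give a lower number than compound 1 remains open. So does the effect of a small amine or a carboxylic acid here.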